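Phenyl for 3-isopropoxypropyl on the amide nitrogen

This account rests on a few compounds, and the source may have more. Where it says the series, first, only, none or still open, it means among the compounds named here.

In an ADME assay on MRC5 cells (Homo sapiens) for inhibition, with a stated time of 72 h (a lower number here means that less compound is needed, a higher number that more compound is needed for the effect), compound 1 (`COc1cccc(OC)c1C(=O)Nc1c[nH]nc1C(=O)O`) gives > 50000 nM, a limit of the assay. Compound 3 (`COc1cccc(OC)c1C(=O)Nc1c[nH]nc1C(=O)NCCCOC(C)C`) gives > 50000 nM, also a limit. Compound 3 thus stands at the limit of > 50000 nM in this assay, at which 2 of the 3 values shown sit. The benzylamino analogue, compound 2 (`COc1cccc(OC)c1C(=O)Nc1c[nH]nc1C(=O)NCc1ccccc1`), reads 50000 nM. Compound 4 (`COc1cccc(OC)c1C(=O)Nc1c[nH]nc1C(=O)Nc1ccccc1`) carries phenyl in place of 3-isopropoxypropyl on an amide-type nitrogen, phenyl in place of 3-isopropoxypropyl on an amide-type nitrogen. The bearing steps are a number no higher from compound 1 to compound 2 (the limit leaves the size open) and a number no lower from compound 2 to compound 3 (the limit leaves the size open), and neither gives a readable size. For the measured compounds named here, the expectation therefore rests on compound 2 at 50000 nM, the only number. The expected change is a number no higher from compound 3 to compound 4 (the limit leaves the size open), with no shift beyond the scatter. Compound 4 is estimated at 50000 nM, within an expected range of 20000 nM to 50000 nM.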

Compound 4, half-maximal effective concentration: > 50000 nM
Compound 4: a limit, no number; the forecaster's own chance of this, stated with the estimate: 70%; the middle value sits exactly at the limit.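

In this assay, the anilino amide shows that phenyl on an amide-type nitrogen, with no saturated chain carbon there, also leaves the series at the limit: the limit of > 50000 nM in this assay, at which 3 of the 4 values shown sit. Of the steps to compound 4, none can be read for size, and only one has a direction: a number no lower from compound 2 to compound 4 (the limit leaves the size open). This change therefore gives no measurable difference between phenyl and 3-isopropoxypropyl.

On these data alone, whether an amine on the chain, or a longer chain ending in morpholine, would give a readable number in this assay stays open.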